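The compounds below may be only part of what the source reports. "The series", "measured", "known", "first", "only" and "open" are said of these compounds alone.

In a physicochemical assay for solubility, read by spectrophotometry, in phosphate buffer, measured as kinetic solubility, with a stated time of 18 h, at pH 7.4 (a higher number here means a more soluble compound, a lower number a less soluble compound), compound 1 `O=C(Nc1ccc(F)c(-c2nc3ccccc3o2)c1)c1cc([N+](=O)[O-])ccc1Cl` gives 270 nM. Two related compounds have also been measured: compound 2 `O=C(Nc1ccc(F)c(-c2nc3ccccc3s2)c1)c1cc([N+](=O)[O-])ccc1Cl` gives 490 nM, and compound 3 `COc1ccc(-c2nc3ccccc3s2)cc1NC(=O)c1cc([N+](=O)[O-])c(N2CCC(C(=O)O)CC2)cc1Cl` gives 210 nM. The number for compound 1 lies within the usual scatter of each of these, so repeat measurements alone could account for those gaps, and its standing among the three is not firmly settled.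

The next compound to consider is compound 4 `O=C(Nc1cccc(-c2nc3ccccc3o2)c1)c1cc([N+](=O)[O-])ccc1Cl`, which is made from compound 1 by one small edit: hydrogen in place of fluoro on an aromatic carbon. In short, hydrogen takes the place of fluoro on an aromatic carbon.

Going by the values given here, only one measured step connects two compounds that differ in a single place: a 1.8-fold higher number from compound 1 to compound 2 (0.26 log units; within the scatter). That step swaps 1,3-benzoxazol-2-yl for 1,3-benzothiazol-2-yl, so it involves a different group from the one changing now, and it stays within the scatter. Compound 3 differs from compound 1 in more than one place, so it cannot isolate a single edit. Among the compounds with values here, no measured pair tests the loss of fluoro directly.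

With so little evidence, no step beyond the scatter is expected in this assay, and no direction can be favoured. The expected step is a 1.0-fold higher number from compound 1 to compound 4 (0.02 log units; within the scatter). For compound 4 the estimated value is 280 nM, with an expected range from 130 nM to 600 nM.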

Compound 4, solubility: 470 nM
Compound 4: middle estimate off by 1.7-fold (0.22 log units), on the low side, within the range that was stated.
By their numbers in this assay, from the lowest: compounds 3, 1, 4 and 2 (each within the scatter of the next, the first and the last beyond it).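

In this assay, the one direct test of this position is a 1.7-fold higher number from compound 1 to compound 4 (0.24 log units; within the scatter). This gap between fluoro and hydrogen lies within the scatter. The earlier step between compounds differing in one place concerned the 1,3-benzoxazol-2-yl group itself, whereas this pair looks at the aromatic carbon ortho to that group and para to a large group, and it shows that, on this core, losing this single fluorine produces no change that stands clear of the scatter. No measurement on hand offers an explanation for the size or direction of this small gap.

The compounds shown place only fluoro and hydrogen at this position, so it remains open whether a bigger or quite different group, such as trifluoromethyl, a nitrile or an amine, would produce a step beyond the scatter. Going by these compounds, it also remains open whether hydrogen in place of fluoro would behave the same way when a 1,3-benzothiazol-2-yl group stands in place of the 1,3-benzoxazol-2-yl group, since this single pair speaks for one core only.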